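The source may hold more compounds than are shown below. What is called first, only, known or untested is meant among the compounds shown, and "the series" means these compounds.

In an ADME assay on L6 cells (Rattus norvegicus) for cytotoxicity, read by resazurin assay (on this read-out higher numbers stand for weaker inhibition and lower numbers for stronger inhibition), compound 1 `N=C(N)c1ccc2[nH]c(-c3ccc4nc(-c5ccc(F)c(F)c5)[nH]c4c3)nc2c1` gives 29.8 ug/mL. With the same core, compound 2 `CC(C)(C)c1cccc(-c2nc3ccc(-c4nc5cc(C(=N)N)ccc5[nH]4)cc3[nH]2)c1O` gives 13.4 ug/mL, a lower number by a gap beyond the usual scatter, so compound 1 holds the higher of the two actual numbers. Compound 3 `N=C(N)c1ccc2[nH]c(-c3ccc4nc(-c5cc(F)ccc5Oc5ccc(Cl)cc5)[nH]c4c3)nc2c1` gives > 90 ug/mL, which is a limit and not a number. Compound 4 `N=C(N)c1ccc2[nH]c(-c3ccc4nc(-c5cccc6ccccc56)[nH]c4c3)nc2c1` differs from compound 1 in one group: naphthalen-1-yl in place of 3,4-difluorophenyl on an aromatic carbon. Among the compounds with values here, no measured pair shows this swap directly, so the expectation in this assay is tentative. A moderate step to a lower number, meaning stronger inhibition, is expected: a 2.1-fold lower number from compound 1 to compound 4 (0.33 log units; beyond the scatter). For compound 4 the estimated value is 14 ug/mL, with an expected range from 5 ug/mL to 40 ug/mL.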

Compound 4, half-maximal inhibitory concentration: 8.72 ug/mL
Estimate against measurement, compound 4: 1.6-fold (0.21 log units) above; low and high end bracket the measured number.
By their numbers in this assay, from the lowest: compounds 4 and 2 (each within the scatter of the next); then compound 1. At a limit, above all of these: compound 3.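

Within the data shown here, this gives the first single-change comparison at this position, on the aromatic carbon between two ring nitrogen atoms. In this assay, naphthalen-1-yl in place of 3,4-difluorophenyl gives a 3.4-fold lower number from compound 1 to compound 4 (0.53 log units; beyond the scatter), so changing this group alone can shift the result. The data shown offer no explanation for this shift. Still open, from the compounds shown here alone, is how naphthalen-2-yl would compare at this position, and whether an aromatic ring carrying an amine or a carboxylic acid would move the number in either direction.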